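Swapping the Amine on a Long-Chain Amide

The compounds below may be only part of what the source reports. "The series", "measured", "known", "first", "only" and "open" are said of these compounds alone.

Compound 3 `CCCCCCCCCCCCCCCCCC(=O)N[C@H](C)c1ccccc1` is a long saturated chain ending in a carbonyl joined to (1-phenylethyl)amino. In a functional assay on U-251 cells (Homo sapiens) for antiproliferative activity, read by sulforhodamine B assay, with a stated time of 48 h (a lower number here means a stronger inhibitor of growth, a higher number a weaker inhibitor of growth), compound 3 gives 161 ug/mL, the highest number among the three measured compounds. Among the compounds with values here, its nearest neighbour is compound 1 `CCCCCCCCCCCCCCCCCC(=O)N1CCOCC1`, which gives 39.9 ug/mL; the step of a 4.0-fold higher number from compound 1 to compound 3 (0.61 log units; beyond the scatter) is the one measured change that directly involves compound 3. Compound 2 `CCCCCCCCCCCCCCCC(=O)N1CCCC1` gives 4.6 ug/mL, the lowest number seen.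

Compound 4 `CCCCCCCCCCCCCCCCCC(=O)N1CCCC1` differs from compound 3 in one place: pyrrolidin-1-yl in place of (1-phenylethyl)amino on a carbonyl carbon. Within the data shown here, no measured step matches this exact exchange. Two observations point the way. Compound 2, which also carries pyrrolidin-1-yl on a carbonyl carbon but on a shorter saturated chain, gives 4.6 ug/mL. The chain of compound 4 is shared by compound 1, which gives 39.9 ug/mL. Both sit well beneath compound 3. The expected step of a 16-fold lower number from compound 3 to compound 4 (1.21 log units; beyond the scatter) is therefore a fall beyond the scatter, towards lower numbers. Compound 4 is estimated at 10 ug/mL, expected to lie between 3 ug/mL and 40 ug/mL.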

Compound 4, concentration for 50% growth inhibition: 8 ug/mL
Estimate against measurement, compound 4: 1.3-fold (0.10 log units) above, within the range that was stated.
By their numbers in this assay, from the lowest: compounds 2 and 4 (each within the scatter of the next); then compound 1; then compound 3.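

On the carbonyl carbon of one and the same long saturated chain, pyrrolidin-1-yl in place of (1-phenylethyl)amino gives a 20-fold lower number from compound 3 to compound 4 (1.30 log units; beyond the scatter) in this assay, and pyrrolidin-1-yl in place of morpholin-4-yl gives a 5.0-fold lower number from compound 1 to compound 4 (0.70 log units; beyond the scatter), so the group on the carbonyl carbon changes the number on this chain whichever of the two it replaces. The chain itself shows no such effect here: with pyrrolidin-1-yl held constant, the ethyl extension far along the chain gives a 1.7-fold higher number from compound 2 to compound 4 (0.24 log units; within the scatter), a difference within the scatter. No supporting data are available to explain these differences.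

From the compounds shown here alone, whether a piperidin-1-yl or a dimethylamino group on the carbonyl carbon would give a number closer to that of pyrrolidin-1-yl or of morpholin-4-yl remains open. So does whether a still longer chain carrying pyrrolidin-1-yl would stay within the scatter of compound 4.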